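The compounds below may be only part of what the source reports. "The series", "measured", "known", "first", "only" and "open" are said of these compounds alone.

Compound 1 `Oc1ccccc1-c1cc(-c2ccccc2F)cc(-c2ccccc2O)n1` was tested in a functional assay on HeLa cells (Homo sapiens) for inhibition; a lower number here means a stronger inhibitor, a higher number a weaker inhibitor. In this assay compound 1 gave only a limit, > 50000 nM. Compound 2 `Oc1cccc(-c2cc(-c3ccccc3F)cc(-c3ccccc3O)n2)c1` gave 31100 nM in this assay, so that an at least 1.6-fold lower number from compound 1 to compound 2 (0.20 log units; that floor lies within the scatter) follows the change (3-hydroxyphenyl in place of 2-hydroxyphenyl on an aromatic carbon). Compound 3 `Oc1cccc(-c2cc(-c3cccc(OC(F)(F)F)c3)cc(-c3ccccc3O)n2)c1` gave 14900 nM in this assay, the lowest of the two numbers, with compound 2 nearest at a step beyond the scatter; how the core of compound 3 differs from that of compound 1 is not broken down here. Compound 4 `Oc1cccc(-c2cc(-c3cccc(OC(F)(F)F)c3)cc(-c3cccc(O)c3)n2)c1` has not yet been measured. It differs from compound 3 by 3-hydroxyphenyl in place of 2-hydroxyphenyl on an aromatic carbon, the same kind of change as from compound 1 to compound 2, though the surroundings differ: meta to a 3-hydroxyphenyl group and a large group, rather than to a 2-fluorophenyl group and a 2-hydroxyphenyl group. Resting on compound 1 and compound 2, whose step was an at least 1.6-fold lower number from compound 1 to compound 2 (0.20 log units; that floor lies within the scatter), a step of a 1.9-fold lower number from compound 3 to compound 4 (0.27 log units; within the scatter) is expected. Compound 4 is therefore estimated at 8000 nM, between 3000 nM and 25000 nM.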

Compound 4, half-maximal inhibitory concentration: > 50000 nM
Compound 4: no number, only a limit; the forecaster's own chance of this, stated with the estimate: 5%; at least 6.2-fold (0.79 log units) between middle value and limit.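

In this assay, 3-hydroxyphenyl in place of 2-hydroxyphenyl gave an at least 3.3-fold higher number from compound 3 to compound 4 (0.52 log units; beyond the scatter). The change therefore did not carry over in the same way from the core of compound 1 to that of compound 3, and the two steps differ: the same change on two cores in this assay, an at least 1.6-fold lower number (0.20 log units; that floor lies within the scatter) from compound 1 to compound 2 and an at least 3.3-fold higher number (0.52 log units; beyond the scatter) from compound 3 to compound 4, at least 5.3-fold (0.73 log units) apart, beyond the scatter of two such steps. What this does not show is the true size of either step or the reason for the gap, since each step has an assay limit at one end rather than a number: the limit of > 50000 nM in this assay, at which 2 of the 4 values shown sit.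

The compounds shown leave open whether the change would behave the same way with other groups on the shared core. They also leave open how an amine or a carboxylic acid in place of the hydroxy group would read in this assay.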